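Methyl for chloro on the aryl sulfonamide of compound 3

The source may report more compounds than this note shows. Statements on the series, on what has been measured and on what is new or still open speak of the compounds shown alone.

Compound 1 `Cc1ccc(S(=O)(=O)N[C@@H]2CC[C@@H](O)[C@H]2C/C=C\CCCC(=O)O)cc1`: 5800 nM
Compound 2 `O=C(O)CCC/C=C\C[C@H]1/C(=N/OCC2CCCCC2)CC[C@@H]1NS(=O)(=O)c1ccc(F)cc1`: 1800 nM
Compound 3 `O=C(O)CC/C=C\C[C@@H]1[C@@H](NS(=O)(=O)c2ccc(Cl)cc2)CC[C@@H]1O`: 1800 nM

In a functional assay (plasma) for inhibition, with Homo sapiens as the target (on this read-out higher numbers stand for weaker inhibition and lower numbers for stronger inhibition), compound 3 gives 1800 nM, level with compound 2 at the digits shown, and the two sit together at the low end of the three numbers; compound 1 gives a number beyond the scatter higher. Compound 4 `Cc1ccc(S(=O)(=O)N[C@H]2CC[C@H](O)[C@@H]2C/C=C\CCC(=O)O)cc1` differs from compound 3 only by methyl in place of chloro on an aromatic carbon. Among the compounds with values here, no pair of measured compounds isolates this exchange, and compound 1, the other bearer of a 4-methylphenyl, differs from compound 4 in more than one place. The step in this assay from compound 3 to compound 4 is therefore expected to be small, a 1.6-fold higher number from compound 3 to compound 4 (0.19 log units; within the scatter), within the scatter. For compound 4 an estimate of 2800 nM is given, between 1200 nM and 6500 nM.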

Compound 4, half-maximal inhibitory concentration: 2500 nM
Compound 4: the middle estimate sits 1.1-fold (0.05 log units) above what was measured; measured number inside the range.
By their numbers in this assay, from the lowest: compounds 2, 3 and 4 (each within the scatter of the next); then compound 1.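

In this assay methyl in place of chloro gives a 1.4-fold higher number from compound 3 to compound 4 (0.14 log units; within the scatter) and so, on this aromatic carbon para to a large group, the two substituents cannot be told apart. Within the data shown here, this is the first single-place change, and it shows that 4-chlorophenyl can give way to 4-methylphenyl without a step beyond the scatter. No supporting measurement is available to explain this result. As far as these compounds go, whether a methoxy group, an amine or a trifluoromethyl group at this place would also leave the number within the scatter remains open.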